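Replacing 3,4-dimethoxyphenyl in compound 1 with 4-fluorophenyl

A few compounds are considered here, and "the series" means these few. Any claim that something is new, unique, unknown or untested is made for them only; others in the source may bear on it.

Among the compounds with values here, in a functional assay on A549 cells (Homo sapiens) for cytotoxicity, read by sulforhodamine B assay, with a stated time of 48 h (on this read-out lower numbers stand for stronger inhibition and higher numbers for weaker inhibition), compound 1 `COc1ccc(-c2cc(C(=O)/C=C/c3cccc(OC)c3OC)ccc2N)cc1OC` gives 6540 nM, the higher of the two numbers so far, and compound 2 `COc1ccc(/C=C/C(=O)c2ccc(N)c(-c3ccc(OC)c(OC)c3)c2)c(OC)c1` gives 2210 nM. Compound 3 `COc1cccc(/C=C/C(=O)c2ccc(N)c(-c3ccc(F)cc3)c2)c1OC` carries 4-fluorophenyl in place of 3,4-dimethoxyphenyl on an aromatic carbon. Within the data shown here, no measured step touches this place. The only one, a 3.0-fold lower number from compound 1 to compound 2 (0.47 log units; beyond the scatter), is modest, changes the 2,3-dimethoxyphenyl instead, and offers a rough scale but no direction. The expected change is small: a 1.3-fold lower number from compound 1 to compound 3 (0.12 log units; within the scatter). In this assay the estimate for compound 3 is 5000 nM, with an expected range of 2000 nM to 13000 nM.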

Compound 3, half-maximal inhibitory concentration: 13300 nM
Beside the measured number, compound 3's estimate is 2.7-fold (0.42 log units) below it; the whole stated range lies below it.
By their numbers in this assay, from the lowest: compound 2; then compound 1; then compound 3.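

In this assay, the place ortho to an amino group proves sensitive to its aryl group: 4-fluorophenyl in place of 3,4-dimethoxyphenyl gives a weaker result (a 2.0-fold higher number from compound 1 to compound 3 (0.31 log units; beyond the scatter)). Changes at this place and on the 2,3-dimethoxyphenyl are now both seen to move the number, each modestly. Nothing measured here gives a reason for this step.

Still open, from the compounds shown here alone, is whether the step follows the departure of the methoxy groups or the arrival of fluorine. A plain phenyl or a 4-methoxyphenyl at this place would separate the two.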